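From chloro to amino: an expected fall

The source may report more compounds than this note shows. Statements on the series, on what has been measured and on what is new or still open speak of the compounds shown alone.

Measured in a physicochemical assay for lipophilicity; on this read-out higher numbers stand for higher lipophilicity and lower numbers for lower lipophilicity
Compound 1 `COc1ccc(CN(CCN(C)C)c2ccccc2)cc1` gives 3.9
Compound 2 `COc1ccc(CN(CCN(C)C)c2ccc(Cl)cc2)cc1` gives 4.47

Of these two compounds, compound 2 stands higher, with 4.47 as its value, and compound 1 lies below it beyond the scatter. Compound 3 `COc1ccc(CN(CCN(C)C)c2ccc(N)cc2)cc1` has not yet been measured. Its change from compound 2 is amino in place of chloro on an aromatic carbon and puts amino in place of chloro on an aromatic carbon, para to a large group.

Among the measured compounds shown here, only one measured step bears on this change. Chloro in place of hydrogen on an aromatic carbon gave a number 0.57 log units higher from compound 1 to compound 2 (beyond the scatter) as a modest rise. Losing the chloro might be expected to take that rise back, towards compound 1 at 3.9 in the shared core. For the measured compounds named here, no measured step shows what amino itself does, so any further fall is a judgement, and the wide range reflects that. Going by the values given here, the expected change is a number 1.57 log units lower from compound 2 to compound 3 (beyond the scatter) as a fall larger than the one measured step. For compound 3 the estimated value is 2.9 with 2.4 to 3.4 as its expected range.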

Compound 3, partition coefficient: 3.13
Beside the measured number, compound 3's estimate is 0.23 log units below it; measured number inside the range.
By their numbers in this assay, from the lowest: compound 3; then compound 1; then compound 2.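

In this assay, this position on an aromatic carbon, para to a large group, now proves able to move the number in either direction from the hydrogen of compound 1. Chloro had given a rise (a number 0.57 log units higher from compound 1 to compound 2 (beyond the scatter)), whereas amino gives a fall (a number 0.77 log units lower from compound 1 to compound 3 (beyond the scatter)), so the amino compound ends up below the hydrogen compound and not merely back level with it. Exchanging one group for the other therefore spans a large step (a number 1.34 log units lower from compound 2 to compound 3 (beyond the scatter)), greater than either step from hydrogen taken alone, and no measurement given here accounts for the size or direction of these changes.

These three compounds leave open whether other groups at this same place, such as hydroxyl, methyl or a carboxylic acid, would fall on the chloro side or the amino side of the hydrogen compound. They also leave open whether the amino step would keep its size if a substituted amine, such as dimethylamino, stood there in its place, or if the same exchange were carried out on a different core.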